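Swapping a Methyl-Bearing Ring for a Fluorine-Bearing Ring

The source may report more compounds than this note shows. Statements on the series, on what has been measured and on what is new or still open speak of the compounds shown alone.

Two compounds in this small series carry a number. Compound 1 `O=C1OC[C@H](Cc2ccccc2)[C@H]1Cc1ccc(Cl)cc1Cl` in a functional assay on HeLa cells (Homo sapiens) for cytotoxicity, read by WST assay, with a stated time of 48 h (on this read-out lower numbers stand for an effect already at smaller amounts and higher numbers for an effect only at larger amounts of compound), gives 23000 nM. Compound 2 `CCOc1ccccc1C[C@H]1COC(=O)[C@@H]1Cc1ccc(Cl)c(Cl)c1` in this assay gives 31000 nM. These two readings lie close enough that the usual scatter of the measurement covers the gap between them.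

Compound 3 `Cc1ccccc1C[C@H]1COC(=O)[C@@H]1Cc1ccc(Cl)c(Cl)c1` was included in the study, but in this assay compound 3 is recorded as "not determined" (no result reported), so it stands without a number of its own. Compound 4 `O=C1OC[C@H](Cc2ccc(F)cc2)[C@H]1Cc1ccc(Cl)c(Cl)c1` has not yet been measured. It differs from compound 3 in one place: 4-fluorophenyl in place of 2-methylphenyl on a saturated chain carbon bound to a saturated ring carbon.

Within the data shown here, no pair of measured compounds in the set differs in only one place, so there is no measured step to lean on. With the two reported values sitting where they do, the expectation is that the change from compound 3 to compound 4 produces no shift beyond the scatter and that compound 4 lands near those readings. In this assay compound 4 is estimated at 26000 nM, expected to fall between 9000 nM and 80000 nM.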

Compound 4, half-maximal effective concentration: 19000 nM
Compound 4: the middle estimate sits 1.4-fold (0.14 log units) above what was measured, and the stated range covers the measured number.
By their numbers in this assay, from the lowest: compounds 4, 1 and 2 (each within the scatter of the next).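

With no number for compound 3 in this assay, the step from it to compound 4 cannot be read. The compounds shown leave open what 4-fluorophenyl in place of 2-methylphenyl does on its own in this assay. No supporting data bear on these readings.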